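Swapping the amine-side heteroaryl in two agonist amides

This account rests on a few compounds, and the source may have more. Where it says the series, first, only, none or still open, it means among the compounds named here.

Compound 1 `CCN(Cc1cccnc1)C(=O)COc1ccc(C)cc1`: 15400 nM
Compound 2 `CCN(Cc1cccs1)C(=O)COc1ccc2c(c1)COC2`: 61 nM

In an assay on HEK293 cells for agonist activity at transient receptor potential cation channel subfamily M member 8 (Homo sapiens), read by fluorescence and calcium flux, with a stated time of 15 min (a lower number here means that less compound is needed, a higher number that more compound is needed for the effect), compound 1 gives 15400 nM, the higher of the two numbers recorded. Within the data shown here, compound 2 gives 61 nM, a lower number by a margin well beyond the scatter, but compound 2 differs from compound 1 in more than one place, so the two values show only that the pair sits far apart, not which change carries the gap. Compound 3 `CCN(Cc1nccs1)C(=O)COc1ccc(C)cc1` keeps the core of compound 1 and alters one place: 1,3-thiazol-2-yl in place of pyridin-3-yl on a saturated chain carbon bound to an amide-type nitrogen. Among the measured compounds shown here, no measured pair isolates this change. The step in this assay is expected to be modest and toward a lower number, a 3.1-fold lower number from compound 1 to compound 3 (0.49 log units; beyond the scatter), with considerable uncertainty. Compound 3 is accordingly estimated at 5000 nM, within a range from 1000 nM to 25000 nM.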

Compound 3, half-maximal effective concentration: 3060 nM
Beside the measured number, compound 3's estimate is 1.6-fold (0.21 log units) above it; the range from low to high includes it.
By their numbers in this assay, from the lowest: compound 2; then compound 3; then compound 1.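

In this assay, the swap of 1,3-thiazol-2-yl for pyridin-3-yl on a saturated chain carbon bound to an amide-type nitrogen gives a 5.0-fold lower number from compound 1 to compound 3 (0.70 log units; beyond the scatter) with the rest of compound 1 unchanged. Among these compounds, this is the first reading of a single change, and it shows that this position alone can move the number beyond the scatter, something the comparison of compound 1 with compound 2 could not separate. Nothing available here explains why the number shifts with this swap.

From the compounds shown here alone, whether phenyl or 1,3-oxazol-2-yl in the same place would give a lower or a higher number remains open. It is also unsettled how the swap would behave on another core, since compound 2 differs from compound 3 in more than one place.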